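The source may report more compounds than this note shows. Statements on the series, on what has been measured and on what is new or still open speak of the compounds shown alone.

Compound 3 `CCCON1C(=O)[C@@H](NC(=O)OCCCCC2CCCCC2)[C@@H]1C` gives 133 nM in an assay on HEK293 cells for inhibition of N-acylethanolamine-hydrolyzing acid amidase (Homo sapiens), read by fluorescence, with stated times of 10 min and 50 min; on this read-out lower numbers stand for stronger inhibition and higher numbers for weaker inhibition. Compound 1 `CN1C[C@H](NC(=O)OCCCCC2CCCCC2)C1=O` gives 1980 nM. Compound 2 `COC(=O)N1C[C@H](NC(=O)OCCCCC2CCCCC2)C1=O` gives 7180 nM.

Among these three, compound 3 stands at the lowest number: compound 1 is nearest to it, compound 2 furthest. For the measured compounds named here, the only step between compounds that differ in one place, a 3.6-fold higher number from compound 1 to compound 2 (0.56 log units; beyond the scatter), concerns a methoxycarbonyl in place of methyl on an amide-type nitrogen in a ring and does not touch the part of the molecule that changes here.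

Compound 4 `CCCCCON1C(=O)[C@@H](NC(=O)OCCCCC2CCCCC2)[C@@H]1C` differs from compound 3 by ethyl in place of hydrogen on a saturated chain carbon, three bonds along the chain from an oxygen on an unsaturated carbon. Going by the values given here, no measured pair bears on this change; compounds 1 and 2 share neither the core of compound 3 nor the alkoxy group on its ring nitrogen, so they offer no guide to lengthening that chain. With nothing to point in either direction, the expectation for this assay rests on the value of compound 3 alone, and a step of no more than modest size, in either direction, is expected, with a wide range to cover the uncertainty.

Compound 4 is therefore expected to give about 110 nM in this assay, within 35 nM to 350 nM, which means an expected step of a 1.2-fold lower number from compound 3 to compound 4 (0.08 log units; within the scatter).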

Compound 4, half-maximal inhibitory concentration: 387 nM
Beside the measured number, compound 4's estimate is 3.5-fold (0.55 log units) below it, outside the stated range (above it).
By their numbers in this assay, from the lowest: compound 3; then compound 4; then compound 1; then compound 2.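

In this assay, ethyl in place of hydrogen on a saturated chain carbon, three bonds along the chain from an oxygen on an unsaturated carbon, gives a 2.9-fold higher number from compound 3 to compound 4 (0.46 log units; beyond the scatter) and so shows that this position is not indifferent to the change. For the compounds shown here, this is the first measured reading at this place, since the earlier step concerned a different part of the molecule, and it shows that going from propyl to pentyl raises the number modestly but beyond the scatter. No supporting data are available to account for the direction or size of this step.

As far as these compounds go, with propyl and pentyl alone, it remains open whether the number would keep rising with a longer chain, or whether methyl, ethyl or a chain ending in an amine or a carboxylic acid would give a lower number. The compounds shown also leave open whether the same lengthening would produce a step of similar size on a different core.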